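Propyl in place of hydrogen: expectation for compound 4

The compounds below may be only part of what the source reports. "The series", "measured", "known", "first", "only" and "open" are said of these compounds alone.

Three members of the series have numbers in a functional assay on the whole organism for inhibition, with Rattus norvegicus as the target, at a dose of 1 mg/kg by the oral route; a higher number here means a stronger effect of the compound at the dose given, a lower number a weaker effect. Compound 1 `CCOc1cc(C(=O)Nc2nn[nH]n2)nc(-c2ccccc2)c1` gives 29%, compound 2 `Cc1cc(C(=O)Nc2nn[nH]n2)nc(-c2ccccc2)c1` gives 23%, and compound 3 `COc1cccc(-c2cc(C)cc(C(=O)Nc3nn[nH]n3)n2)c1` gives 25%. Compound 2 holds the lowest of the three numbers, but each step to it stays within the scatter: a number 6 percentage points lower from compound 1 to compound 2 (within the scatter) and a number 2 percentage points higher from compound 2 to compound 3 (within the scatter). Compound 4 `CCCc1ccc(-c2cc(C)cc(C(=O)Nc3nn[nH]n3)n2)cc1` is not yet measured and differs from compound 2 by propyl in place of hydrogen on an aromatic carbon. For the measured compounds named here, no measured step puts a group at this position; the only measured entry of a group onto an aromatic carbon stayed within the scatter, so the step to compound 4 is expected to be a number 2 percentage points higher from compound 2 to compound 4 (within the scatter), nothing beyond the scatter. Compound 4 is estimated at 25%, within 10% to 42%.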

Compound 4, a percentage reported as inhibition, in the whole organism at one dose (the size of the read-out at that dose, not a potency): 65%
Estimate against measurement, compound 4: 40 percentage points below, outside the stated range (above it).
By their numbers in this assay, from the lowest: compounds 2, 3 and 1 (each within the scatter of the next); then compound 4.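

Propyl on an aromatic carbon of a six-membered aromatic ring of carbon only, para to a large group, gives the only step in the series beyond the scatter in this assay: a number 42 percentage points higher from compound 2 to compound 4 (beyond the scatter). The methoxy step, a number 2 percentage points higher from compound 2 to compound 3 (within the scatter), stayed within the scatter, so a group entering this ring does not alone bring a large change, though that step differs in both group and place. No measured data bear on why propyl has this effect. Still open, on these data alone, is whether a longer chain such as butyl, or an amine or a carboxylic acid, at this place would give a similar number. Methyl or ethyl there would show how much of the chain is needed.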